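Cytotoxicity notes on the series, compound 3 to compound 4

The compounds below may be only part of what the source reports. "The series", "measured", "known", "first", "only" and "open" are said of these compounds alone.

Measured so far in an ADME assay on HEK293 cells (Homo sapiens) for cytotoxicity, read by MTT assay, with a stated time of 72 h; on this read-out higher numbers stand for weaker inhibition and lower numbers for stronger inhibition:
compound 1, `COc1ccc(C2=C(c3cc(OC)c(OC)c(OC)c3)CC(O[SiH2]C(C)(C)C)C2=O)cc1[N+](=O)[O-]`, a limit: > 100 ug/mL.
compound 2, `COc1ccc(C2=C(c3cc(OC)c(OC)c(OC)c3)C(=O)C(O[SiH2]C(C)(C)C)C2)cc1OC(C)C`, a limit: > 100 ug/mL.
compound 3, `C=CCOc1cc(C2=C(c3cc(OC)c(OC)c(OC)c3)C(=O)C(O)C2)ccc1OC`, a limit: > 100 ug/mL.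

Compound 3 stands only at a limit of this assay, with no number of its own. The two other values shown are limits as well, so the whole set sits at the limit of > 100 ug/mL in this assay, at which 3 of the 3 values shown sit. Compound 4, `COc1ccc(C2=C(c3cc(OC)c(OC)c(OC)c3)C(=O)C(O)C2)cc1`, is not yet measured; it differs from compound 3 by hydrogen in place of allyloxy on an aromatic carbon, the allyloxy leaving the aromatic carbon ortho to a methoxy group. No step between measured compounds is shown, and no step beyond the scatter is expected in this assay. Compound 4 is expected at 150 ug/mL, range 60 ug/mL to 400 ug/mL, most likely again reported only as a limit, the expected step being a step that the limit leaves unreadable from compound 3 to compound 4.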

Compound 4, half-maximal inhibitory concentration: 6.3 ug/mL
Compound 4: middle estimate off by 24-fold (1.38 log units), on the high side; the measured number lies below the stated range.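

In this assay, hydrogen in place of allyloxy on the aromatic carbon ortho to a methoxy group gives an at least 15-fold lower number from compound 3 to compound 4 (1.20 log units; beyond the scatter), the first sign in this set that the read-out responds to a change at this position. Compound 4 alone carries a number of its own, so the size of the step is only a bound: the limit of > 100 ug/mL in this assay, at which 3 of the 4 values shown sit.

On these data alone, whether any group at this position would hold the value at the limit, or allyloxy alone does so, stays open. A hydroxyl, an amine or a longer chain there would separate these cases.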